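Swapping a hexyl for a hydroxyethyl on the sulfur

The source may hold more compounds than are shown below. What is called first, only, known or untested is meant among the compounds shown, and "the series" means these compounds.

Three measured compounds share one core and differ only in the group attached to a sulfur. In a functional assay on MOLT-4 cells (Homo sapiens) for cytotoxicity (on this read-out higher numbers stand for weaker inhibition and lower numbers for stronger inhibition), compound 1 `Cc1cn([C@H]2C[C@H](SSc3ccccc3[N+](=O)[O-])[C@@H](CO)O2)c(=O)[nH]c1=O` gives 31000 nM, compound 2 `C=CCSS[C@H]1C[C@H](n2cc(C)c(=O)[nH]c2=O)O[C@@H]1CO` gives 34000 nM, and compound 3 `CCCCCCSS[C@H]1C[C@H](n2cc(C)c(=O)[nH]c2=O)O[C@@H]1CO` gives 27000 nM. Compound 3 stands lowest of these three numbers, yet the steps of a 1.1-fold lower number from compound 1 to compound 3 (0.06 log units; within the scatter) and a 1.3-fold lower number from compound 2 to compound 3 (0.10 log units; within the scatter) both lie within the scatter, as does a 1.1-fold higher number from compound 1 to compound 2 (0.04 log units; within the scatter). Compound 4 `Cc1cn([C@H]2C[C@H](SSCCO)[C@@H](CO)O2)c(=O)[nH]c1=O` carries hydroxy in place of butyl on a saturated chain carbon, two bonds along the chain from a sulfur. Every measured step exchanges the group on this sulfur without moving the number beyond the scatter, so no step beyond the scatter is expected here either, in either direction. Compound 4 is therefore estimated at 30000 nM in this assay, with a range from 12000 nM to 75000 nM. The implied step a 1.1-fold higher number from compound 3 to compound 4 (0.05 log units; within the scatter) is expected to stay small.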

Compound 4, half-maximal inhibitory concentration: 128000 nM
Compound 4: the middle estimate sits 4.3-fold (0.63 log units) below what was measured; the whole stated range lies below it.
By their numbers in this assay, from the lowest: compounds 3, 1 and 2 (each within the scatter of the next); then compound 4.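

In this assay, for the compounds shown here, the group on this sulfur is not interchangeable after all: 2-hydroxyethyl is the first group here to move the number beyond the scatter, with a 4.7-fold higher number from compound 3 to compound 4 (0.68 log units; beyond the scatter) and a 3.8-fold higher number from compound 2 to compound 4 (0.58 log units; beyond the scatter) and also a 4.1-fold higher number from compound 1 to compound 4 (0.62 log units; beyond the scatter). Hexyl, allyl and 2-nitrophenyl, very different groups, stay within the scatter of one another, and only compound 4 stands apart. No measurement on hand explains this rise. On these data alone, it remains open whether the hydroxy or the shorter chain matters; a plain ethyl on the sulfur or a 6-hydroxyhexyl would separate the two.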